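Hydroxy-acyl amides: permeability notes on the tert-butyl step

The compounds below may be only part of what the source reports. "The series", "measured", "known", "first", "only" and "open" are said of these compounds alone.

Measured compounds in an ADME assay on Caco-2 cells (Homo sapiens) for permeability, read by LC-MS, in the apical to basolateral direction, with a stated time of 60 min, at pH 6.5; a higher number here means that the compound crosses the layer faster, a lower number that the compound crosses the layer more slowly:
- compound 1 `CC(C)(C)[C@@H](O)C(=O)N1C[C@@H]2C[C@@H]2[C@H]1C(=O)NCc1cc(Cl)ccc1-n1cnnn1` gives 17 10^-6 cm/s
- compound 2 `O=C(NCc1cc(Cl)ccc1-n1cnnn1)[C@@H]1CCNN1C(=O)[C@H](O)c1ccccc1` gives 5.3 10^-6 cm/s
- compound 3 `O=C(NCc1cc(Cl)ccc1-n1cnnn1)[C@@H]1[C@H]2C[C@H]2CN1C(=O)[C@H](O)c1ccccc1` gives 12 10^-6 cm/s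

Compound 2 has the lowest number of the three, beyond the scatter against both compound 3 and compound 1. Compound 3 and compound 1 share a core and differ by one change, (tert-butyl in place of phenyl on a saturated chain carbon bound to a carbonyl carbon and an oxygen on a saturated carbon), which made a step of a 1.4-fold higher number from compound 3 to compound 1 (0.15 log units; within the scatter) in this assay. Compound 2 has a different core from compound 3; the difference between the two cores is not broken down here.

Compound 4 `CC(C)(C)[C@@H](O)C(=O)N1NCC[C@H]1C(=O)NCc1cc(Cl)ccc1-n1cnnn1` is not yet measured. It stands to compound 2 as compound 1 stands to compound 3: the change is tert-butyl in place of phenyl on a saturated chain carbon bound to a carbonyl carbon and an oxygen on a saturated carbon, the same kind of change, at the same place in words. Among the measured compounds shown here, only one earlier example of this change is at hand, and it lay within the scatter, so a step of similar size is expected from compound 2 to compound 4, about a 1.4-fold higher number from compound 2 to compound 4 (0.14 log units; within the scatter), resting on the measured step of a 1.4-fold higher number from compound 3 to compound 1 (0.15 log units; within the scatter). In this assay compound 4 is therefore estimated at 7.4 10^-6 cm/s, with a range from 4 10^-6 cm/s to 13 10^-6 cm/s expected.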

Compound 4, apparent permeability: 7.2 10^-6 cm/s
Beside the measured number, compound 4's estimate is 1.0-fold (0.01 log units) above it; low and high end bracket the measured number.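

In this assay tert-butyl in place of phenyl gives a 1.4-fold higher number from compound 2 to compound 4 (0.13 log units; within the scatter) and sits close to the earlier example of the same change: the same change on two cores in this assay, a 1.4-fold higher number (0.15 log units; within the scatter) from compound 3 to compound 1 and a 1.4-fold higher number (0.13 log units; within the scatter) from compound 2 to compound 4, 1.0-fold (0.02 log units) apart, within the scatter of two such steps. On the two cores shown, the step therefore carries over with a similar small size, and the core makes no resolved difference to it. This does not show that the change moves the read-out in either direction, since each step lies within the scatter, and two cores are too few to establish a rule for the whole series.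

The compounds shown leave open whether an amine, a carboxylic acid or a longer chain, placed on a saturated chain carbon bound to a carbonyl carbon and an oxygen on a saturated carbon, would give a step of a similar size in this assay. They also leave open whether the small step between phenyl and tert-butyl would hold on a third core.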